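A few compounds are considered here, and "the series" means these few. Any claim that something is new, unique, unknown or untested is made for them only; others in the source may bear on it.

Measured so far in a functional assay on MCF7 cells (Homo sapiens) for antiproliferative activity, read by MTT assay, with a stated time of 72 h; a lower number here means a stronger inhibitor, a higher number a weaker inhibitor:
compound 1, `Cc1cc(NCCN(C)C)nc2ccc(NC(=O)c3ccc(Cl)c(Cl)c3)cc12`, gives 2550 nM
compound 2, `Cc1cc(NCCN2CCN(C)CC2)nc2ccc(NC(=O)c3ccc(Cl)c(Cl)c3)cc12`, gives 1700 nM

Among the measured compounds shown here, compound 2 carries the lower of the two numbers, but the only step, a 1.5-fold lower number from compound 1 to compound 2 (0.18 log units; within the scatter), lies within the scatter, so the two compounds are not separated by this assay.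

Compound 3 is `Cc1cc(NCCN2CCCC2)nc2ccc(NC(=O)c3ccc(Cl)c(Cl)c3)cc12`. Against compound 2 the difference is:
pyrrolidin-1-yl in place of 4-methylpiperazin-1-yl on a saturated chain carbon, two bonds along the chain from a nitrogen on an aromatic ring

For the measured compounds named here, the one measured step that bears on this place is a 1.5-fold lower number from compound 1 to compound 2 (0.18 log units; within the scatter): there a different amine at the same saturated chain carbon moved the number only within the scatter. Nothing else in the set touches this position. The expected step is therefore a 1.2-fold higher number from compound 2 to compound 3 (0.07 log units; within the scatter), which is no change beyond the scatter, with the estimate leaning neither way. On that basis compound 3 is expected to give 2000 nM in this assay, with a range from 900 nM to 4500 nM.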

Compound 3, half-maximal inhibitory concentration in the MCF7 assay: 1280 nM
Compound 3: middle estimate off by 1.6-fold (0.19 log units), on the high side, within the range that was stated.
By their numbers in the MCF7 assay, from the lowest: compounds 3, 2 and 1 (each within the scatter of the next).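

In the MCF7 assay the steps of a 1.3-fold lower number from compound 2 to compound 3 (0.12 log units; within the scatter) and a 2.0-fold lower number from compound 1 to compound 3 (0.30 log units; within the scatter) leave dimethylamino, 4-methylpiperazin-1-yl and pyrrolidin-1-yl unseparated at this saturated chain carbon, so a third amine adds no measurable difference to the first pair. In a physicochemical assay for lipophilicity, at pH 7.4 (a higher number here means a more lipophilic compound, a lower number a more polar compound), compound 2 gives 1.73 and compound 3 gives 1.72, so replacing the six-membered ring with 2 hetero atoms by the five-membered ring with 1 hetero atom also stays within the scatter in this second read-out. No measurement at hand offers an explanation for either result.

Open, as far as these compounds go, is whether a morpholin-4-yl group, a primary amine, a carboxylic acid or a longer chain at this place would move the number in the MCF7 assay beyond the scatter. Also open, from the compounds shown here alone, is whether a change elsewhere on the shared core would do so.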